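The source may hold more compounds than are shown below. What is called first, only, known or untested is meant among the compounds shown, and "the series" means these compounds.

Compound 1 `C=C1[C@H](C)CCC[C@]1(C)CC/C(C)=C/CC1=C(O)C(=O)C=C(N[C@@H](C(=O)O)[C@@H](C)O)C1=O`: > 10 ug/mL, a limit.
Compound 2 `C=C1[C@H](C)CCC[C@]1(C)CC/C(C)=C/CC1=C(O)C(=O)C=C(NCC(=O)O)C1=O`: 4 ug/mL.

Among the measured compounds shown here, in an ADME assay on KB cells (Homo sapiens) for cytotoxicity, with a stated time of 48 h (a lower number here means a stronger inhibitor, a higher number a weaker inhibitor), compound 2 gives 4 ug/mL, the only actual number so far. Compound 3 `C=C1[C@H](C)CCC[C@]1(C)CC/C(C)=C/CC1=C(O)C(=O)C=C(N[C@H](C(=O)O)[C@H](C)O)C1=O` differs from it as follows: 1-hydroxyethyl in place of hydrogen on a saturated chain carbon bound to an amine nitrogen and a carbonyl carbon. For the measured compounds named here, one measured step bears on this, the same exchange run the other way: an at least 2.5-fold lower number from compound 1 to compound 2 (0.39 log units; beyond the scatter). Its size is known only as a bound. A move towards weaker inhibition, of similar size and beyond the scatter, is therefore expected. The expected change is a 2.5-fold higher number from compound 2 to compound 3 (0.40 log units; beyond the scatter). The estimate for compound 3 is 10 ug/mL, with an expected range of 4 ug/mL to 25 ug/mL.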

Compound 3, half-maximal inhibitory concentration: > 10 ug/mL
Compound 3 was reported as a limit; the forecaster's own chance of this, stated with the estimate: 50%; the middle value sits exactly at the limit.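

In this assay, 1-hydroxyethyl in place of hydrogen on the saturated chain carbon gives an at least 2.5-fold higher number from compound 2 to compound 3 (0.39 log units; beyond the scatter), the same direction as the step involving compound 1. That direction therefore holds for both drawn configurations, a point resting on this: the fact that compounds 1 and 3 differ only in the configuration as drawn The step between those two compounds cannot be read, and no order between the configurations follows, because both values are limits: the limit of > 10 ug/mL in this assay, at which 2 of the 3 values shown sit.

As far as these compounds go, the actual values of compound 1 and compound 3 remain open. So does the effect of a methyl, a longer chain or an amine at this carbon.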